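The source may report more compounds than this note shows. Statements on the series, on what has been measured and on what is new or still open speak of the compounds shown alone.

Measured in a functional assay on MCF7 cells (Homo sapiens) for antiproliferative activity; on this read-out lower numbers stand for stronger inhibition and higher numbers for weaker inhibition:
- compound 1 `Cc1cc(-c2nc3ccccc3s2)ccc1N` gives < 1 nM (a limit)
- compound 2 `CC(=O)Nc1ccc(-c2nc3ccccc3s2)cc1C` gives > 10000 nM (a limit)
- compound 3 `CC(=O)N(C(C)=O)c1ccc(-c2nc3ccccc3s2)cc1C` gives > 10000 nM (a limit)

Compound 2 stands at a limit (> 10000 nM) and not at a number. Compound 4 `CC(=O)Nc1ccc(-c2nc3ccccc3s2)cc1[N+](=O)[O-]` differs from it by nitro in place of methyl on an aromatic carbon (nitro in place of methyl on an aromatic carbon, ortho to an acetamido group). Among the compounds with values here, no measured step changes this place. The nearest evidence is at the nitrogen, where the acetamido group of compound 4 is retained: the large at least 10000-fold higher number from compound 1 to compound 2 (4.00 log units; beyond the scatter) and the large at least 10000-fold higher number from compound 1 to compound 3 (4.00 log units; beyond the scatter) stand there, while a step that the two limits leave unreadable from compound 2 to compound 3 tells nothing. Compound 4 is therefore expected to stay with compound 2, with no step beyond the scatter (a step that the limit leaves unreadable from compound 2 to compound 4 expected). For compound 4 the estimated value is 15000 nM with an expected range from 5000 nM to 50000 nM (estimate only).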

Compound 4, half-maximal inhibitory concentration: > 1000 nM
Compound 4: a limit, no number; the forecaster's own chance of this, stated with the estimate: 85%; the middle value is on the limit's open side.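

Compound 2 and compound 4 both stand at limits, not at numbers, and the step between them cannot be read. Going by these compounds, whether nitro in place of methyl changes the read-out at all remains open.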